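Cyclopropylcarbonyl in place of tert-butoxycarbonyl on a quiet series

The source may hold more compounds than are shown below. What is called first, only, known or untested is meant among the compounds shown, and "the series" means these compounds.

Compound 1, `CCN(CC)S(=O)(=O)c1ccc(S(=O)(=O)N2CCC[C@@H](C(=O)NC3CN(C(=O)OC(C)(C)C)C3)C2)cc1`, in a functional assay on MIA PaCa-2 cells (Homo sapiens) for inhibition, read by MTT assay, with a stated time of 3 days; a lower number here means a stronger inhibitor, a higher number a weaker inhibitor: > 10000 nM
Compound 2, `CCOC(=O)[C@@H]1CCC[C@H](S(=O)(=O)c2ccc(S(=O)(=O)N(CC)CC)cc2)C1`, in this assay: > 10000 nM
Compound 3, `CCOC(=O)[C@@H]1CCCN(S(=O)(=O)c2ccc(S(=O)(=O)N(CC)CC)nc2)C1`, in this assay: > 10000 nM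

Of the compounds shown here, three sharing the diethylsulfamoyl-aryl sulfonyl motif have been tested in this assay, and none gave a number. For compound 1 the result is a limit of the assay, > 10000 nM. For compound 2 the result is likewise a limit, > 10000 nM. For compound 3 the result is again a limit, > 10000 nM. Compound 1 therefore stands at the limit of > 10000 nM in this assay, at which 3 of the 3 values shown sit, with nothing to rank it against the other two.

Compound 4, `CCN(CC)S(=O)(=O)c1ccc(S(=O)(=O)N2CCC[C@@H](C(=O)NC3CN(C(=O)C4CC4)C3)C2)cc1`, keeps the whole of compound 1 except at one carbonyl carbon: cyclopropyl in place of tert-butoxy on a carbonyl carbon. For the measured compounds named here, no measured pair shows what such a change does in this assay, so the expectation rests only on where compound 1 stands. A swap of this size, confined to a substituent on the azetidine nitrogen, is expected to move the readout by no more than the usual scatter, in no particular direction, so compound 4 is expected to show a step that the limit leaves unreadable from compound 1 to compound 4. Compound 4 is accordingly estimated at 15000 nM, within 5000 nM to 50000 nM, and most likely to be reported as a limit as well.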

Compound 4, half-maximal inhibitory concentration: > 10000 nM
Compound 4: only a limit was reported; the forecaster's own chance of this, stated with the estimate: 85%; the middle value does not contradict the limit.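

From the compounds shown here alone, compound 4, like compound 1, gives only a limit in this assay, so no step can be read between these two compounds, and the effect of cyclopropyl in place of tert-butoxy on a carbonyl carbon stays unknown. The compounds shown leave open which structural feature, if any, would give a readable value, for all of them stand at one mark: the limit of > 10000 nM in this assay, at which 4 of the 4 values shown sit.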